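This account rests on a few compounds, and the source may have more. Where it says the series, first, only, none or still open, it means among the compounds named here.

Series notes. In an assay for inhibition of Tryptophan 2,3-dioxygenase (Homo sapiens), with a stated time of 1 h (on this read-out lower numbers stand for stronger inhibition and higher numbers for weaker inhibition), compound 1 `O=C(/C(=N/O)Nc1ccc(F)c(Br)c1)C1CCN(C(=O)NCc2ccccc2)CC1` gives 89800 nM. Compound 2 `O=C(Nc1ccccc1)[C@H]1CC[C@H](C(=O)/C(=N/O)Nc2ccc(F)c(Br)c2)CC1` returns only the limit > 100000 nM in this assay. Compound 3 `O=C(/C(=N/O)Nc1ccc(F)c(Br)c1)C1CCN(S(=O)(=O)Nc2ccccc2)CC1` gives 65700 nM in this assay, the lower of the two numbers, with compound 1 nearest; the step of a 1.4-fold lower number from compound 1 to compound 3 (0.14 log units; within the scatter) lies within the scatter. Compound 4 `NS(=O)(=O)N1CCC(C(=O)/C(=N/O)Nc2ccc(F)c(Br)c2)CC1` is the next member: hydrogen in place of phenyl on a sulfonamide nitrogen. Going by the values given here, no measured step alters the substituent on a sulfonamide nitrogen; the one single-site step, a 1.4-fold lower number from compound 1 to compound 3 (0.14 log units; within the scatter), was within the scatter, and the limit of > 100000 nM in this assay, at which 1 of the 3 values shown sits, shows how close the series sits to the ceiling. For compound 4 the expected step is a 1.4-fold higher number from compound 3 to compound 4 (0.14 log units; within the scatter), nothing beyond the scatter, with a fair chance of only a limit. The estimate for compound 4 is 90000 nM, range 40000 nM to 200000 nM.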

Compound 4, half-maximal inhibitory concentration: 62500 nM
Compound 4: the middle estimate sits 1.4-fold (0.16 log units) above what was measured, and the stated range covers the measured number.
By their numbers in this assay, from the lowest: compounds 4, 3 and 1 (each within the scatter of the next). At a limit, above all of these: compound 2.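

With the phenyl gone from the sulfonamide nitrogen, the read-out in this assay holds: a 1.1-fold lower number from compound 3 to compound 4 (0.02 log units; within the scatter). The plain sulfamoyl group also compares with the larger benzylcarbamoyl on the amine nitrogen in the ring without a step beyond the scatter, so this position has so far tolerated all three groups: a 1.4-fold lower number from compound 1 to compound 4 (0.16 log units; within the scatter). Compound 2 remains a limit, and the series still sits close to the ceiling: the limit of > 100000 nM in this assay, at which 1 of the 4 values shown sits.

Going by these compounds, whether any group on the sulfonamide nitrogen can move the number at all stays open. A methyl group, a longer alkyl chain or a carboxylic acid there would test this.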